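Swapping the halogenated phenyl on an aromatic thiazolethione core

This account rests on a few compounds, and the source may have more. Where it says the series, first, only, none or still open, it means among the compounds named here.

Three compounds share a trimethoxyphenyl group attached to a sulfur-containing five-membered ring, and differ in whether that ring is saturated or aromatic and in the halogenated phenyl it carries. Compound 1 `COc1cc(N2C(=S)SCC2(O)c2ccc(Br)cc2)cc(OC)c1OC` has a saturated ring bearing a 4-bromophenyl group; in a functional assay on MCF7 cells (Homo sapiens) for cytotoxicity, read by MTT assay, with a stated time of 48 h (on this read-out lower numbers stand for stronger inhibition and higher numbers for weaker inhibition), compound 1 gives 16.5 ug/mL. Compound 2 `COc1cc(N2C(=S)SCC2(O)c2ccc(Cl)cc2Cl)cc(OC)c1OC` carries a 2,4-dichlorophenyl group on the same saturated ring, and in this assay compound 2 gives 9.6 ug/mL. The change is a 1.7-fold lower number from compound 1 to compound 2 (0.24 log units; within the scatter), so the two halogen patterns cannot be told apart there.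

Compound 3 `COc1cc(-n2c(-c3ccc(Br)cc3)csc2=S)cc(OC)c1OC` has the aromatic version of the ring with a 4-bromophenyl group. In this assay compound 3 gives > 100 ug/mL, which is a limit of the assay rather than a number; it sits at the limit of > 100 ug/mL in this assay, at which 1 of the 3 values shown sits.

Compound 4 `COc1cc(-n2c(-c3ccc(Cl)cc3Cl)csc2=S)cc(OC)c1OC` is the aromatic-ring counterpart of compound 2. Its change from compound 3 is 2,4-dichlorophenyl in place of 4-bromophenyl on an aromatic carbon. Among the measured compounds shown here, the only comparable step, from compound 1 to compound 2, was within the scatter, so no step beyond the scatter is expected in this assay here either, and compound 3 starts from a limit. Compound 4 is therefore expected to give 100 ug/mL, with a range from 40 ug/mL to 250 ug/mL. The estimate implies a step of a number no higher from compound 3 to compound 4 (the limit leaves the size open), most likely remaining at the limit.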

Compound 4, half-maximal inhibitory concentration: 23.6 ug/mL
For compound 4 the middle estimate is 4.2-fold (0.63 log units) above the measured one, and the stated range ends above it.
By their numbers in this assay, from the lowest: compounds 2, 1 and 4 (each within the scatter of the next, the first and the last beyond it). At a limit, above all of these: compound 3.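

On the aromatic core, this halogen swap matters in a way the saturated core gave no sign of: this assay shows an at least 4.2-fold lower number from compound 3 to compound 4 (0.62 log units; beyond the scatter). The same swap on the saturated core gave a 1.7-fold lower number from compound 1 to compound 2 (0.24 log units; within the scatter), so among these four compounds, what the exchange does depends on the core that carries it, and a result on one core did not carry over to the other. Compound 3 stands at a limit of the assay and not at a number, so the step to compound 4 has a known lowest size but no known full size: the limit of > 100 ug/mL in this assay, at which 1 of the 4 values shown sits.

The swap changes two things at once, removing a bromine and bringing in two chlorines, so the compounds shown cannot say which of these produces the step, or why it appears on the aromatic core alone. A 4-chlorophenyl group or a plain phenyl group on the same aromatic carbon would help separate these changes, and a 4-methoxyphenyl group would show whether a halogen is needed there at all.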